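The source may hold more compounds than are shown below. What is called first, only, known or untested is meant among the compounds shown, and "the series" means these compounds.

In an assay for displacement of a labelled ligand from Nicotinic acetylcholine receptor alpha8 subunit (Periplaneta americana), read by scintillation counting, with a stated time of 2 h, at 24 degrees C (on this read-out lower numbers stand for stronger inhibition and higher numbers for weaker inhibition), compound 1 `Oc1ccc(/C=C2\CCN=C2c2cccnc2)cc1` gives 310 nM. Compound 2 `COc1ccc(/C=C2\CCN=C2c2cccnc2)cc1` sits at a limit of the assay, > 10000 nM. Compound 3 `Fc1ccc(/C=C2\CCN=C2c2cccnc2)cc1` likewise sits at a limit, > 10000 nM. The step of an at least 32-fold higher number from compound 1 to compound 2 (1.50 log units; beyond the scatter) and the step of an at least 32-fold higher number from compound 1 to compound 3 (1.50 log units; beyond the scatter) are both large, and in each case the number ends at the limit of > 10000 nM in this assay, at which 2 of the 3 values shown sit. Among the compounds with values here, the step that the two limits leave unreadable from compound 2 to compound 3 cannot be read, since compound 2 and compound 3 show only that neither reaches a number. Compound 3 thus stands at the weak end of what the three results show, at a limit rather than a value.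

Compound 4 `Clc1ccc(/C=C2\CCN=C2c2cccnc2)cc1` differs from compound 3 by chloro in place of fluoro on an aromatic carbon. Within the data shown here, no measured step covers this change; the two large steps from compound 1 show only that compound 2 and compound 3, which lack the hydroxy group, both sit at the limit. In this assay one therefore expects no step beyond the scatter and estimates a step that the limit leaves unreadable from compound 3 to compound 4. Compound 4 is expected to give 12000 nM, within 3000 nM to 50000 nM.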

Compound 4, half-maximal inhibitory concentration: > 10000 nM
Compound 4 gave a limit, no number; the forecaster's own chance of this, stated with the estimate: 65%; the middle value does not contradict the limit.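

In this assay compound 4 also sits at a limit of the assay, > 10000 nM. Chloro thus joins methoxy and fluoro as a third group at this position, para to a large group, that gives no number in place of the hydroxy group. The step of an at least 32-fold higher number from compound 1 to compound 4 (1.50 log units; beyond the scatter) leaves compound 1 as the only one of the four with a number, and the steps among compound 2, compound 3 and compound 4 cannot be read, so these three groups cannot be ranked: the limit of > 10000 nM in this assay, at which 3 of the 4 values shown sit.

On these data alone, it remains open whether an amine or a carboxylic acid at this position would give a number, as the hydroxy group of compound 1 does. Also open, as far as these compounds go, is how much weaker compound 2, compound 3 and compound 4 truly are, since their results are limits.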